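The source may hold more compounds than are shown below. What is called first, only, known or untested is meant among the compounds shown, and "the series" means these compounds.

Compound 1 `COc1ccc(C(=O)/C=C/c2cc(-c3cc(OC)c(OC)c(OC)c3)n3nc(-c4ccccc4)cc3n2)cc1` is the reference point of this small set: in a functional assay on A549 cells (Homo sapiens) for antiproliferative activity, read by MTT assay, with a stated time of 24 h (on this read-out lower numbers stand for stronger inhibition and higher numbers for weaker inhibition), compound 1 gives 14600 nM. Compound 2 `COc1cc(-c2cc(/C=C/C(=O)c3ccccc3)nc3cc(-c4ccccc4)nn23)cc(OC)c1OC` differs from it by hydrogen in place of methoxy on an aromatic carbon, and in this assay compound 2 gives 18200 nM, so that a 1.2-fold higher number from compound 1 to compound 2 (0.10 log units; within the scatter). Compound 3 `COc1ccc(C(=O)/C=C/c2cc(-c3ccc(OC)cc3)n3nc(-c4ccccc4)cc3n2)cc1` differs from compound 1 by 4-methoxyphenyl in place of 3,4,5-trimethoxyphenyl on an aromatic carbon; in this assay compound 3 gives 2900 nM, and a 5.0-fold lower number from compound 1 to compound 3 (0.70 log units; beyond the scatter). Compound 3 thus stands lowest of the three numbers, with compound 1 and compound 2 both beyond the scatter above it.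

Compound 4 `COc1ccc(-c2cc(/C=C/C(=O)c3ccccc3)nc3cc(-c4ccccc4)nn23)cc1` has not yet been measured. It differs from compound 3 by hydrogen in place of methoxy on an aromatic carbon, the same change that separates compound 1 from compound 2, made here on the core of compound 3. From compound 1 to compound 2 that change moved the number only within the scatter, and the expectation rests on that single pairing: a similarly small step, a 1.2-fold higher number from compound 3 to compound 4 (0.08 log units; within the scatter), is expected. On that basis, compound 4 is expected to give about 3500 nM in this assay, most likely between 1500 nM and 8000 nM.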

Compound 4, half-maximal inhibitory concentration: 8600 nM
The estimate for compound 4 lay 2.5-fold (0.39 log units) below the measured number; measured number above the stated range.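

Hydrogen in place of methoxy on an aromatic carbon gave a 3.0-fold higher number from compound 3 to compound 4 (0.47 log units; beyond the scatter) in this assay, and although only this step lies beyond the scatter, it does not differ measurably from the step on the core of compound 1: the same change on two cores in this assay, a 1.2-fold higher number (0.10 log units; within the scatter) from compound 1 to compound 2 and a 3.0-fold higher number (0.47 log units; beyond the scatter) from compound 3 to compound 4, 2.4-fold (0.38 log units) apart, within the scatter of two such steps

4-Methoxyphenyl in place of 3,4,5-trimethoxyphenyl gave a 2.1-fold lower number from compound 2 to compound 4 (0.33 log units; beyond the scatter), in the same direction as on the core of compound 1, and here too the two steps do not differ beyond their combined scatter: the same change on two cores in this assay, a 5.0-fold lower number (0.70 log units; beyond the scatter) from compound 1 to compound 3 and a 2.1-fold lower number (0.33 log units; beyond the scatter) from compound 2 to compound 4, 2.4-fold (0.38 log units) apart, within the scatter of two such steps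

Among these compounds, each change therefore carried from one core to the other without a detectable difference in size, but with only two pairs per change this does not show that the steps are equal or that either would hold on further cores.

From the compounds shown here alone, it remains open whether a hydroxyl group, a chlorine atom or an amine in place of that methoxy would follow the same trend. Going by these compounds, it is also open whether either step would persist if the phenyl on the shared core carried a carboxylic acid.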